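A few compounds are considered here, and "the series" means these few. Any claim that something is new, unique, unknown or untested is made for them only; others in the source may bear on it.

Measured in a functional assay on HT-29 cells (Homo sapiens) for cytotoxicity, read by MTT assay, with a stated time of 72 h; a higher number here means a weaker inhibitor, a lower number a stronger inhibitor:
- compound 1 `COc1ccc(-c2cc(/N=C3/NC(=O)CS3)cs2)cc1`: > 50000 nM (a limit)
- compound 2 `COc1cccc(N2C(=O)CS/C2=N\c2csc(-c3ccccc3)c2)c1`: 38300 nM

Among the measured compounds shown here, compound 2, at 38300 nM, gives the only actual number so far. The entry for compound 1, > 50000 nM, is a limit of this assay and not a number.

Compound 3 `COc1ccc(-c2cc(/N=C3\SCC(=O)N3c3cccc(OC)c3)cs2)cc1` has not been measured. It differs from compound 2 by methoxy in place of hydrogen on an aromatic carbon, so phenyl becomes 4-methoxyphenyl. For the measured compounds named here, no measured pair shows this change, so the only anchor is compound 2 at 38300 nM. In this assay, the expected step of a 1.1-fold lower number from compound 2 to compound 3 (0.03 log units; within the scatter) is none beyond the scatter, with no direction favoured. Compound 3 is estimated at 36000 nM, with an expected range of 15000 nM to 50000 nM.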

Compound 3, half-maximal inhibitory concentration: 11700 nM
Compound 3: the middle estimate sits 3.1-fold (0.49 log units) above what was measured; the measured number lies below the stated range.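

In this assay, among the compounds shown here, methoxy in place of hydrogen, para to a large group, turns phenyl into 4-methoxyphenyl and gives a 3.3-fold lower number from compound 2 to compound 3 (0.52 log units; beyond the scatter), the first readable step at this position. With this change, compound 3 reaches 11700 nM, the lowest number among the compounds shown. The 3-methoxyphenyl on the amide-type nitrogen in a ring gives an at least 4.2-fold lower number from compound 1 to compound 3 (0.63 log units; beyond the scatter), a step whose starting point is a limit of the assay and not a number: the limit of > 50000 nM in this assay, at which 1 of the 3 values shown sits.

The compounds shown leave open whether an amine, a carboxylic acid or a longer chain such as ethoxy at this place would shift the number the same way as methoxy. They also leave open whether 4-methoxyphenyl gives a similar step when the ring nitrogen carries a group other than 3-methoxyphenyl.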